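This account rests on a few compounds, and the source may have more. Where it says the series, first, only, none or still open, it means among the compounds named here.

Compounds measured:
compound 1, `Nc1c([S+]([O-])CCCF)sc2nc(-c3cccs3)cc(-c3ccccc3)c12`, 6.1 nM
compound 2, `CCCC[S+]([O-])c1sc2nc(-c3nccs3)cc(-c3ccc(C(=O)OC)cc3)c2c1N`, 15.1 nM

In an assay for inhibition of 15-hydroxyprostaglandin dehydrogenase [NAD(+)] (Homo sapiens), read by fluorescence, with a stated time of 15 min, in the presence of a further agent that is not named here (a higher number here means a weaker inhibitor, a lower number a stronger inhibitor), compound 1 holds the lowest of the two numbers; compound 2 lies at a higher number, and the gap between them is beyond the scatter. Compound 3, `CCCCCC[S+]([O-])c1sc2nc(-c3cccs3)cc(-c3ccccc3)c2c1N`, is not yet measured. It differs from compound 1 by propyl in place of fluoro on a saturated chain carbon, three bonds along the chain from a sulfur. Going by the values given here, no measured pair shows this change, so the step from compound 1 to compound 3 in this assay is expected to be small, within or barely beyond the scatter, if anything toward a slightly higher number: a 1.3-fold higher number from compound 1 to compound 3 (0.12 log units; within the scatter). Compound 3 is thus estimated at 8 nM, in the range 3 nM to 25 nM.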

Compound 3, half-maximal inhibitory concentration: 18 nM
Beside the measured number, compound 3's estimate is 2.3-fold (0.35 log units) below it, and the stated range covers the measured number.
By their numbers in this assay, from the lowest: compound 1; then compounds 2 and 3 (each within the scatter of the next).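

In this assay the swap of fluoro for propyl on a saturated chain carbon, three bonds along the chain from a sulfur, gives a 3.0-fold higher number from compound 1 to compound 3 (0.47 log units; beyond the scatter) and so shows that this position responds to the change. The step is modest, and the hexyl chain of compound 3 still leaves a low number in this series. Nothing shown here accounts for the step. The compounds shown leave open whether the loss of fluoro or the added chain length carries the step, and how a butyl chain, or an amine or a carboxylic acid in place of the fluoro, would read.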